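Amine terminus swap on the propoxy chain

A few compounds are considered here, and "the series" means these few. Any claim that something is new, unique, unknown or untested is made for them only; others in the source may bear on it.

Of the compounds shown here, three have numbers so far. Compound 1 `COc1cc2c(Oc3ccc(NC(=O)NN4C(=O)CSC4c4c(F)cccc4F)c(Cl)c3)ccnc2cc1OCCCN1CCCC1` and compound 2 `COc1cc2c(Oc3ccc(NC(=O)NN4C(=O)CSC4c4c(F)cccc4F)cc3Cl)ccnc2cc1OCCCN1CCCC1` carry a pyrrolidinyl end on the side chain and differ from each other in where the chlorine sits; in a functional assay on HT-29 cells (Homo sapiens) for antiproliferative activity, read by MTT assay, with a stated time of 72 h (on this read-out higher numbers stand for weaker inhibition and lower numbers for stronger inhibition), compound 1 gives 630 nM and compound 2 gives 480 nM. Compound 3 `COc1cc2c(Oc3c(F)cc(NC(=O)NN4C(=O)CSC4c4c(F)cccc4F)cc3F)ccnc2cc1OCCCN1CCC(C)CC1` carries two fluorines on the central ring and a 4-methylpiperidin-1-yl end; in this assay compound 3 gives 220 nM, the lowest number of the three, and its gaps to compound 2 and to compound 1 both lie beyond the scatter, so compound 3 is the strongest inhibitor measured here.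

Compound 4 `CCN(CC)CCCOc1cc2nccc(Oc3c(F)cc(NC(=O)NN4C(=O)CSC4c4c(F)cccc4F)cc3F)c2cc1OC` keeps the whole frame of compound 3 and changes only the end of the chain: diethylamino in place of 4-methylpiperidin-1-yl on a saturated chain carbon, three bonds along the chain from an oxygen on an aromatic ring. Within the data shown here, no pair of measured compounds isolates this change, so its size cannot be read from the data. The change is confined to the chain terminus and all three measured compounds, with two different cyclic amines, fall within a narrow band, so a step of modest size is expected, most likely within the scatter, in either direction. The step from compound 3 to compound 4 is estimated at a 1.4-fold higher number from compound 3 to compound 4 (0.13 log units; within the scatter). Compound 4 is expected to give 300 nM in this assay, with a range from 120 nM to 800 nM.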

Compound 4, half-maximal inhibitory concentration: 91 nM
The estimate for compound 4 lay 3.3-fold (0.52 log units) above the measured number; the whole stated range lies above it.
By their numbers in this assay, from the lowest: compound 4; then compound 3; then compounds 2 and 1 (each within the scatter of the next).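

In this assay, diethylamino in place of 4-methylpiperidin-1-yl on a saturated chain carbon, three bonds along the chain from an oxygen on an aromatic ring, gives a 2.4-fold lower number from compound 3 to compound 4 (0.38 log units; beyond the scatter). Among these compounds, this is the first pair that differs in one place, and it shows that a change confined to the chain terminus can by itself move the number beyond the scatter, with the ring-free diethylamino end on the lower side in this frame. Among the compounds shown here, nothing measured so far bears on what lies behind this step.

This single pair cannot separate the loss of the ring from the loss of the methyl group, and it holds only for the frame with two fluorines on the central ring shared by compound 3 and compound 4. Still open, going by these compounds, are whether the step carries over to the chlorine-bearing frames of compound 1 and compound 2, and how a dimethylamino, morpholin-4-yl or unsubstituted piperidin-1-yl end would read at the same place.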